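This account rests on a few compounds, and the source may have more. Where it says the series, first, only, none or still open, it means among the compounds named here.

Compound 3 `CC(C)N(Cc1cccc(OCCCCCC(=O)O)c1)C(=O)c1ccc(-c2ccc3cc[nH]c3c2)cc1` was tested in an ADME assay on BJ cells (Homo sapiens) for cytotoxicity, read by CellTiter-Glo and resazurin assay, with a stated time of 72 h (on this read-out lower numbers stand for an effect already at smaller amounts and higher numbers for an effect only at larger amounts of compound), and for compound 3 the read-out > 26000 nM is a limit of the assay, not a number. Two further values among the three shown are also limits: compound 1 `CC(C)N(Cc1cccc(OCCCCCC(=O)O)c1)C(=O)c1ccc(-c2cccc3ccccc23)cc1` gives < 1.3 nM, a limit. Compound 2 `CC(C)Oc1cccc(-c2ccc(C(=O)N(Cc3cccc(OCCCCCC(=O)O)c3)C(C)C)cc2)c1` gives > 26000 nM, a limit as well.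

Compound 4 `CC(C)N(Cc1cccc(OCCCCCC(=O)O)c1)C(=O)c1ccc(-c2cccc(OC(F)(F)F)c2)cc1` differs from compound 3 by 3-(trifluoromethoxy)phenyl in place of 1H-indol-6-yl on an aromatic carbon. The measured steps that speak to this place are an at least 20000-fold higher number from compound 1 to compound 2 (4.30 log units; beyond the scatter) and an at least 20000-fold higher number from compound 1 to compound 3 (4.30 log units; beyond the scatter), while a step that the two limits leave unreadable from compound 2 to compound 3. Because compound 2 sits at the limit of > 26000 nM in this assay, at which 2 of the 3 values shown sit, compound 4, which also carries a six-membered carbon ring at this place, is expected to land near the same limit, so the estimated a number no higher from compound 3 to compound 4 (the limit leaves the size open) is none beyond the scatter. Compound 4 is estimated at 26000 nM, with a range from 5000 nM to 100000 nM.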

Compound 4, half-maximal effective concentration: > 26000 nM
Compound 4 gave a limit, no number; the forecaster's own chance of this, stated with the estimate: 70%; the middle value sits exactly at the limit.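

Placing 3-(trifluoromethoxy)phenyl where compound 1 has naphthalen-1-yl gives an at least 20000-fold higher number from compound 1 to compound 4 (4.30 log units; beyond the scatter) in this assay, so trifluoromethyl on the oxygen, like isopropyl in compound 2, does not restore the reading of compound 1. Compound 4 gives a limit, and it is the limit most of the series shares: the limit of > 26000 nM in this assay, at which 3 of the 4 values shown sit. The steps to compound 4 from compound 2 and compound 3 cannot be read, as each joins two limits.

From the compounds shown here alone, how far these three compounds lie beyond that limit stays open. Also open, going by these compounds, is whether naphthalen-2-yl, or a phenyl carrying an amine, would behave like naphthalen-1-yl.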